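Hydrolytic stability notes on the shared core series

The source may hold more compounds than are shown below. What is called first, only, known or untested is meant among the compounds shown, and "the series" means these compounds.

Among the compounds with values here, compound 3 `CC(C)(C)C1=C(C(=O)O)N2C(=O)[C@H]([C@@H](O)CCc3ccc(O)cc3)[C@H]2O1` holds the highest number measured so far in an ADME assay, in phosphate buffer, at 28 degrees C, at pH 7.0 (on this read-out higher numbers stand for a longer-lived compound and lower numbers for a shorter-lived compound), giving 21.2 h. Compound 2 `Cn1cc([C@H](O)[C@H]2C(=O)N3C(C(=O)O)=C(C(C)(C)C)O[C@H]23)nn1` gives 7 h and compound 1 `CC(C)(C)C1=C(C(=O)O)N2C(=O)[C@H](CO)[C@H]2O1` gives 5 h; both gaps to compound 3 are beyond the scatter. Compound 4 `CC(C)(C)C1=C(C(=O)O)N2C(=O)[C@H]([C@@H](O)CCc3ccncc3)[C@H]2O1` differs from compound 3 by pyridin-4-yl in place of 4-hydroxyphenyl on a saturated chain carbon, three bonds along the chain from an oxygen on a saturated carbon and a saturated ring carbon. Within the data shown here, the only measured step in the set, a 1.4-fold higher number from compound 1 to compound 2 (0.15 log units; within the scatter), concerns a substituent on a saturated chain carbon bound to an oxygen, a different place from the present change, and it stayed within the scatter. Among the measured compounds shown here, no measured pair bears directly on the exchange of one six-membered aromatic ring for another at this position, and compound 1 and compound 2 carry no such ring at all. An expected step of a 1.4-fold lower number from compound 3 to compound 4 (0.15 log units; within the scatter) is therefore set near no change, with wide bounds to reflect the lack of a guiding pair. Compound 4 is expected to give 15 h, with a range from 6 h to 40 h.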

Compound 4, half-life: 15.8 h
Compound 4: middle estimate off by 1.1-fold (0.02 log units), on the low side; measured number inside the range.
By their numbers in this assay, from the lowest: compounds 1 and 2 (each within the scatter of the next); then compounds 4 and 3 (each within the scatter of the next).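

In this assay, pyridin-4-yl in place of 4-hydroxyphenyl gives a 1.3-fold lower number from compound 3 to compound 4 (0.13 log units; within the scatter), so in this one pair the loss of the hydrogen-bond donor and the entry of a ring nitrogen leave the half-life unresolved from that of compound 3. Compound 4 also stands clear of the two compounds without this chain, with a 2.3-fold higher number from compound 2 to compound 4 (0.35 log units; beyond the scatter) and a 3.2-fold higher number from compound 1 to compound 4 (0.50 log units; beyond the scatter), so the 2-(pyridin-4-yl)ethyl group is read here as holding a number beyond the scatter of both. No measurement on hand accounts for any of these steps.

As far as these compounds go, whether pyridin-3-yl or pyridin-2-yl would behave as pyridin-4-yl does at this place stays open. So does the outcome with a phenyl ring carrying an amine or a carboxylic acid, or with a longer chain leading to the ring.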